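Cap group variation on a hydroxamic acid series

The source may hold more compounds than are shown below. What is called first, only, known or untested is meant among the compounds shown, and "the series" means these compounds.

Compound 1 `O=C(CCC1=CCN(CCCc2ccc(Cl)cc2)C1=O)NO` and compound 2 `O=C(CCC1=CCN(Cc2ccc(F)cc2)C1=O)NO` share the same core and hydroxamic acid. In a functional assay on NCI-H23 cells (Homo sapiens) for inhibition, read by sulforhodamine B assay (on this read-out higher numbers stand for weaker inhibition of growth and lower numbers for stronger inhibition of growth), compound 1 gives 2520 nM and compound 2 gives 4670 nM; the two numbers sit within the scatter of each other, so compound 2 is not set apart from compound 1 on these data. Compound 3 `CC(C)(C)c1ccc(CN2CC=C(CCC(=O)NO)C2=O)cc1` carries the change (tert-butyl in place of fluoro on an aromatic carbon). For the measured compounds named here, no step between measured compounds guides this change; the expected step of a 1.9-fold lower number from compound 2 to compound 3 (0.27 log units; within the scatter) is small, toward a lower number, and not clearly beyond the scatter. Compound 3 is estimated at 2500 nM, range 900 nM to 7000 nM.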

Compound 3, concentration for 50% growth inhibition: 420 nM
Beside the measured number, compound 3's estimate is 6.0-fold (0.77 log units) above it, and the stated range ends above it.
By their numbers in this assay, from the lowest: compound 3; then compounds 1 and 2 (each within the scatter of the next).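

In this assay tert-butyl in place of fluoro on this aromatic carbon gives an 11-fold lower number from compound 2 to compound 3 (1.05 log units; beyond the scatter) and so stronger inhibition of growth. For the compounds shown here, this is the first step beyond the scatter, and it shows that this carbon takes the larger group and that the group placed there matters to the read-out. Nothing available explains the step. Open, on these data alone, is whether a smaller alkyl such as methyl or isopropyl keeps this gain, or whether a methoxy, an amine or a carboxylic acid at this carbon does. Also open, as far as these compounds go, is whether tert-butyl gives the same step on the longer chain of compound 1.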